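Chloro to tert-butyl: what the one measured step suggests

This account rests on a few compounds, and the source may have more. Where it says the series, first, only, none or still open, it means among the compounds named here.

Of the compounds shown here, two built on a shared core have been measured so far in a functional assay on A549 cells (Homo sapiens) for inhibition, read by MTT assay, with a stated time of 72 h; a lower number here means a stronger inhibitor, a higher number a weaker inhibitor. Compound 1 `Cc1cc(C)cc(CN2CCc3ncn(COCc4ccccc4)c3/C(=C/c3ccccc3)C2=O)c1` gives 22500 nM, and compound 2 `O=C1/C(=C\c2ccccc2)c2c(ncn2COCc2ccccc2)CCN1Cc1ccc(Cl)cc1` gives 11800 nM, so compound 2 stands level with compound 1 once normal scatter is allowed for. Compound 3 `CC(C)(C)c1ccc(CN2CCc3ncn(COCc4ccccc4)c3/C(=C/c3ccccc3)C2=O)cc1` turns the 4-chlorobenzyl of compound 2 into 4-(tert-butyl)benzyl: tert-butyl in place of chloro on an aromatic carbon. In words, tert-butyl takes the place of chloro on an aromatic carbon, para to a large group. Going by the values given here, only one measured step bears on this change: a 1.9-fold lower number from compound 1 to compound 2 (0.28 log units; within the scatter), where 4-chlorophenyl replaced 3,5-dimethylphenyl. With so little evidence, no step beyond the scatter is expected in this assay. The estimated step is a 1.3-fold higher number from compound 2 to compound 3 (0.10 log units; within the scatter). For compound 3 the expected value is 15000 nM, with an estimated range of 6000 nM to 35000 nM.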

Compound 3, half-maximal inhibitory concentration: 20600 nM
For compound 3 the middle estimate is 1.4-fold (0.14 log units) below the measured one, within the range that was stated.
By their numbers in this assay, from the lowest: compounds 2, 3 and 1 (each within the scatter of the next).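

In this assay, putting tert-butyl (4 heavy atoms) in place of chloro (1 heavy atom) on this aromatic carbon gives a 1.7-fold higher number from compound 2 to compound 3 (0.24 log units; within the scatter) and so does not move the result beyond the scatter. The comparison with the 3,5-dimethylphenyl group gives a 1.1-fold lower number from compound 1 to compound 3 (0.04 log units; within the scatter) and also stays within the scatter, so the three aryl groups now seen on this side of the shared core cannot be told apart in this assay. No measurement shown here offers an explanation for this.

Still open, as far as these compounds go, is whether a group of a different kind on this aromatic carbon, such as an amine or a carboxylic acid, would give a step beyond the scatter. Also open, from the compounds shown here alone, is whether changes elsewhere on the shared core would do so.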